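Ethyl ether in place of methyl ether on the styrene arm

This account rests on a few compounds, and the source may have more. Where it says the series, first, only, none or still open, it means among the compounds named here.

Compound 1 `COC(=O)/C=C/c1cccc(N(Cc2ccc(/C=C/c3cc(C(F)(F)F)cc(C(F)(F)F)c3)cc2)C(=O)C(C)C)c1`: in an assay on isolated protein with Bile acid receptor (Homo sapiens) as the target (on this read-out higher numbers stand for an effect only at larger amounts of compound and lower numbers for an effect already at smaller amounts), compound 1 gives 1950 nM.
Compound 2 `CC(C)(C)OC(=O)/C=C/c1ccc(CN(C(=O)C2CCCCC2)c2cccc(/C=C/C(N)=O)c2)cc1`: in this assay compound 2 reaches only the limit > 1000 nM, a limit and not a number.
Compound 3 `COC/C=C/c1cccc(N(Cc2ccc(/C=C/C(=O)OC(C)(C)C)cc2)C(=O)C2CCCCC2)c1`: in this assay compound 3 gives 243 nM.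

Among the numbers shown, compound 3 stands lowest; the nearest number is that of compound 1, and the value of compound 2 is a limit of > 1000 nM in this assay, at which 1 of the 3 values shown sits, rather than a number, so it cannot be ranked against them. Within the data shown here, the one single-point step that has been measured, an at least 4.1-fold lower number from compound 2 to compound 3 (0.61 log units; beyond the scatter), replaces carbamoyl with methoxymethyl on a double-bonded chain carbon bound to a double-bonded chain carbon, and it falls beyond the scatter.

Compound 4 `CCOC/C=C/c1cccc(N(Cc2ccc(/C=C/C(=O)OC(C)(C)C)cc2)C(=O)C2CCCCC2)c1` differs from compound 3 by methyl in place of hydrogen on a saturated chain carbon bound to an oxygen on a saturated carbon, which reads as methoxymethyl to ethoxymethyl. Among the measured compounds shown here, no measured step touches this position in that way; the step from compound 2 to compound 3 exchanges the whole group, not a single methyl on its saturated carbon, and so bears on it only loosely. With nothing to point either way, the step is expected to stay within the scatter, a 1.0-fold higher number from compound 3 to compound 4 (0.01 log units; within the scatter). Compound 4 is therefore estimated at 250 nM in this assay, with a range from 80 nM to 800 nM.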

Compound 4, half-maximal effective concentration: 220 nM
Compound 4: the middle estimate sits 1.1-fold (0.06 log units) above what was measured, and the stated range covers the measured number.
By their numbers in this assay, from the lowest: compounds 4 and 3 (each within the scatter of the next); then compound 1.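

In this assay, the methyl that turns methoxymethyl into ethoxymethyl, set on a saturated chain carbon bound to an oxygen on a saturated carbon, does not separate the two compounds: a 1.1-fold lower number from compound 3 to compound 4 (0.04 log units; within the scatter). The difference from the carbamoyl group on the double-bonded chain carbon therefore no longer rests on a single ether, since ethoxymethyl shows it as methoxymethyl did: an at least 4.5-fold lower number from compound 2 to compound 4 (0.65 log units; beyond the scatter). This step gives only a lower bound on the size of the change, not its full size, and compound 2 has a limit rather than a number: the limit of > 1000 nM in this assay, at which 1 of the 4 values shown sits.

What the compounds shown leave open is how far this end of the ether can be extended, since a longer chain such as propoxymethyl, a branched isopropoxymethyl or a benzyloxymethyl group could still stay level with compound 3 or part from it. They also leave open whether the ether oxygen matters at all, a question that a hydroxymethyl group, an aminomethyl group or a plain propyl chain in the same place would address.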